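Swapping the outer halophenyl group on a lysophosphatidylserine mimic

A few compounds are considered here, and "the series" means these few. Any claim that something is new, unique, unknown or untested is made for them only; others in the source may bear on it.

Measured compounds:
Compound 1, `CCCCCCCCCCCOc1ccccc1CCC(=O)OCCCOP(=O)(O)OC[C@H](N)C(=O)O`, gives 0.04 in an assay on cells for activation of probable G-protein coupled receptor 34 (Mus musculus), with a stated time of 1 h; a higher number here means a larger maximal response, a lower number a smaller maximal response.
Compound 2, `N[C@@H](COP(=O)(O)OCCCOC(=O)CCc1ccccc1OCCCCCCOc1ccccc1)C(=O)O`, gives 0.071 in this assay.
Compound 3, `N[C@@H](COP(=O)(O)OCCCOC(=O)CCc1ccccc1OCc1cccc(Oc2ccccc2Cl)c1)C(=O)O`, gives 0.069 in this assay.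

All three responses are small compared with the reference agonist, and the values of compound 3, compound 2 and compound 1 all lie within the usual scatter of one another, so none can be told apart on these numbers. For the measured compounds named here, the only single-point step measured so far, a number 0.031 higher from compound 1 to compound 2 (within the scatter), concerns the far end of the chain, not the part changed here.

Compound 4, `N[C@@H](COP(=O)(O)OCCCOC(=O)CCc1ccccc1OCc1cccc(Oc2ccc(I)cc2)c1)C(=O)O`, is compound 3 with a different outer ring: 4-iodophenyl in place of 2-chlorophenyl on an oxygen on an aromatic ring. Going by the values given here, no measured step touches this position, and the one step available stayed within the scatter. The step a number 0.0010 higher from compound 3 to compound 4 (within the scatter) is therefore expected to be small, with no clear direction. Compound 4 is estimated to give about 0.07 in this assay, between 0.02 and 0.15.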

Compound 4, intrinsic activity: the largest response reached, as a fraction of the reference agonist's: 0.82
Compound 4: middle estimate off by 0.75, on the low side; the measured number lies above the stated range.
By their numbers in this assay, from the lowest: compounds 1, 3 and 2 (each within the scatter of the next); then compound 4.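

The outer ring on this oxygen matters: in this assay the change from 2-chlorophenyl to 4-iodophenyl gives a number 0.75 higher from compound 3 to compound 4 (beyond the scatter) and is the first step shown that stands beyond the scatter. The two rings have the same count of heavy atoms and neither carries a hydrogen-bond donor or acceptor, so these counts do not separate them. Nothing available here bears on why the response changes so much.

This single step changes both the halogen and its place on the ring, so it cannot show which of the two accounts for the rise. On these data alone, a 4-chlorophenyl or a 2-iodophenyl group on the same oxygen would separate the two, and whether a 4-bromophenyl group behaves like 4-iodophenyl also stays open.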